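Compound 3 and one added methyl

This account rests on a few compounds, and the source may have more. Where it says the series, first, only, none or still open, it means among the compounds named here.

Measured in a functional assay on HCT-116 cells (Homo sapiens) for inhibition, read by sulforhodamine B assay, with a stated time of 96 h (on this read-out higher numbers stand for weaker inhibition of growth and lower numbers for stronger inhibition of growth), so far:
- compound 1 `CC[C@@H](Nc1nc(NCc2ccccn2)c2ncn(C(C)C)c2n1)C(C)O` gives 18000 nM in this series
- compound 2 `CC[C@@H](Nc1nc(NCc2ccccn2)c2ncn(C(C)C)c2n1)C(O)C(C)(C)C` gives 29000 nM in this series
- compound 3 `CC[C@H](Nc1nc(NCc2ccccn2)c2ncn(C(C)C)c2n1)C(C)O` gives 10000 nM in this series

Compound 3 stands with compound 1 at the low end of these three numbers. The gap between them is small (a 1.8-fold lower number from compound 1 to compound 3 (0.26 log units; within the scatter)), whereas compound 2 lies further off (a 2.9-fold lower number from compound 2 to compound 3 (0.46 log units; beyond the scatter)). That second step mixes a change of group with a difference in drawn configuration, so it says little about size alone.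

In compound 4 `CCC(O)[C@H](CC)Nc1nc(NCc2ccccn2)c2ncn(C(C)C)c2n1` the 1-hydroxyethyl of compound 3 becomes 1-hydroxypropyl (methyl in place of hydrogen on a saturated chain carbon, two bonds along the chain from an oxygen on a saturated carbon). The nearest measured guide is the much larger swap of tert-butyl in place of methyl on a saturated chain carbon bound to an oxygen. Even that swap stayed inside the scatter (a 1.6-fold higher number from compound 1 to compound 2 (0.21 log units; within the scatter)), and it pointed towards a slightly higher number. A single methyl on the same chain is therefore expected to do no more, so a shift beyond the scatter in this assay is not expected. The expected change is small (a 1.2-fold higher number from compound 3 to compound 4 (0.08 log units; within the scatter)). Compound 4 is estimated at 12000 nM in a range from 6000 nM to 24000 nM on this read-out.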

Compound 4, concentration for 50% growth inhibition: 29000 nM
Compound 4: middle estimate off by 2.4-fold (0.38 log units), on the low side; the whole stated range lies below it.
By their numbers in this assay, from the lowest: compounds 3, 1, 2 and 4 (each within the scatter of the next, the first and the last beyond it).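

In this assay, a single added methyl on a saturated chain carbon, two bonds along the chain from an oxygen on a saturated carbon, gives a 2.9-fold higher number from compound 3 to compound 4 (0.46 log units; beyond the scatter), a modest step but one beyond the scatter. This shows that the end of this chain is not indifferent to a small change, which the earlier tert-butyl swap, at a 1.6-fold higher number from compound 1 to compound 2 (0.21 log units; within the scatter), had not shown. The other two steps stay within the scatter, at no change at the digits printed from compound 2 to compound 4 (within the scatter) and a 1.6-fold higher number from compound 1 to compound 4 (0.21 log units; within the scatter), so the ethyl end of compound 4 and the much larger tert-butyl end of compound 2 read alike, and the number does not simply follow the size of the group across these compounds.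

How much of the step from compound 3 depends on configuration stays open, and the pair of compound 1 and compound 3 cannot settle that: the fact that one of compounds 1 and 3 is drawn with a defined configuration and the other without, at the place where they differ The compounds shown also leave open how a longer chain such as 1-hydroxybutyl, or an amine in place of the hydroxyl, would read at this position.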